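This account rests on a few compounds, and the source may have more. Where it says the series, first, only, none or still open, it means among the compounds named here.

Compound 1 `Nc1nc(Nc2ccc(S(N)(=O)=O)cc2)sc1C(=O)c1cccnc1` gives 20000 nM in a functional assay on GC-1 cells (Mus musculus) for cytotoxicity, read by MTT assay, with a stated time of 72 h; a lower number here means a stronger inhibitor, a higher number a weaker inhibitor.
Compound 2 `Nc1nc(Nc2ccc(S(N)(=O)=O)cc2)sc1C(=O)c1cccc(F)c1` gives 6400 nM.
Compound 3 `Nc1nc(Nc2ccc(S(N)(=O)=O)cc2)sc1C(=O)c1cccc([N+](=O)[O-])c1` gives 22000 nM.

Compound 3 carries the highest of the three numbers, with compound 1 nearest: that gap, a 1.1-fold higher number from compound 1 to compound 3 (0.04 log units; within the scatter), lies within the scatter. Compound 2 stands furthest off, the step of a 3.4-fold higher number from compound 2 to compound 3 (0.54 log units; beyond the scatter) being beyond the scatter. Compound 4 `COc1cccc(C(=O)c2sc(Nc3ccc(S(N)(=O)=O)cc3)nc2N)c1` differs from compound 3 in one place: methoxy in place of nitro on an aromatic carbon. Among the measured compounds shown here, the only measured step that touches the same group is the one from fluoro to nitro, a 3.4-fold higher number from compound 2 to compound 3 (0.54 log units; beyond the scatter), which raised the number by a modest amount; no measured compound carries a methoxy, so the step to compound 4 is expected to be small, leaning lower, as a 1.8-fold lower number from compound 3 to compound 4 (0.26 log units; within the scatter). Compound 4 is therefore estimated at 12000 nM, within 5000 nM to 30000 nM.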

Compound 4, half-maximal inhibitory concentration: 9100 nM
For compound 4 the middle estimate is 1.3-fold (0.12 log units) above the measured one, within the range that was stated.
By their numbers in this assay, from the lowest: compounds 2 and 4 (each within the scatter of the next); then compounds 1 and 3 (each within the scatter of the next).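

Replacing nitro with methoxy gives a 2.4-fold lower number from compound 3 to compound 4 (0.38 log units; beyond the scatter), so the higher number seen with nitro is not shared by every other group tried at this position. Methoxy and fluoro cannot be told apart, at a 1.4-fold higher number from compound 2 to compound 4 (0.15 log units; within the scatter), and the replacement of pyridin-3-yl by 3-methoxyphenyl gives a 2.2-fold lower number from compound 1 to compound 4 (0.34 log units; beyond the scatter), a step in the same direction as the one to 3-fluorophenyl. No measurement at hand bears on the reason for these steps. Going by these compounds, whether an amine, a carboxylic acid or a longer alkoxy chain at this position would fall with fluoro and methoxy or with nitro remains open.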